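The source may report more compounds than this note shows. Statements on the series, on what has been measured and on what is new or still open speak of the compounds shown alone.

Of the compounds shown here, three that differ in one place have been measured in a physicochemical assay for acid dissociation. Compound 1 `COc1cccc(Oc2ccc3c(NCCCNCc4cc(F)ccc4OC)ccnc3c2)c1`, which carries 3-methoxyphenoxy, gives 9.28. Compound 2 `COc1ccc(-c2ccc3c(NCCCNCc4cc(F)ccc4OC)ccnc3c2)cc1`, which carries 4-methoxyphenyl, gives 9.47. Compound 3 `COc1ccc(F)cc1CNCCCNc1ccnc2cc(CCC(C)C)ccc12`, which carries isopentyl, gives 9.47. Compound 3 therefore stands level with compound 2 at the digits shown, and compound 1 lies within the scatter of both.

The next compound is compound 4 `COc1ccc(F)cc1CNCCCNc1ccnc2cc(Oc3ccc(Cl)cc3)ccc12`, which is related to compound 3 by the following change: 4-chlorophenoxy in place of isopentyl on an aromatic carbon. In short, 4-chlorophenoxy takes the place of isopentyl on an aromatic carbon.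

Within the data shown here, three measured steps bear on this change. The closest is the exchange between 3-methoxyphenoxy and isopentyl, which showed a number 0.19 log units higher from compound 1 to compound 3 (within the scatter). The other two showed a number 0.19 log units higher from compound 1 to compound 2 (within the scatter) and no change at the digits printed from compound 2 to compound 3 (within the scatter). No step among these three compounds leaves the scatter, although no compound with a 4-chlorophenoxy group has yet been measured. A small move in the direction of compound 1 at 9.28 is therefore expected, and nothing beyond the scatter. The expected change is a number 0.17 log units lower from compound 3 to compound 4 (within the scatter). The estimate for compound 4 is 9.3, with an expected range from 9 to 9.6.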

Compound 4, acid dissociation constant: 9.28
Estimate against measurement, compound 4: 0.02 log units above, within the range that was stated.
By their numbers in this assay, from the lowest: compounds 1, 4, 2 and 3 (each within the scatter of the next).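

In this assay, putting 4-chlorophenoxy in place of isopentyl gives a number 0.19 log units lower from compound 3 to compound 4 (within the scatter) and shows that a group with 8 heavy atoms, an aromatic ring and a hydrogen-bond acceptor can replace a ring-free group of 5 carbons at this position while the number stays within the scatter. Putting 4-chlorophenoxy in place of 4-methoxyphenyl gives a number 0.19 log units lower from compound 2 to compound 4 (within the scatter) and adds a chlorine-bearing group to the set, again without leaving the scatter. Keeping the oxygen on the aromatic carbon and putting 4-chlorophenyl in place of 3-methoxyphenyl on that oxygen gives no change at the digits printed from compound 1 to compound 4 (within the scatter) and offers a comparison between two phenoxy groups that the earlier compounds could not provide. Nothing shown here gives a reason for these numbers.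

Going by these compounds, whether an amine, a carboxylic acid or a longer chain at this position would also stay within the scatter remains open. On these data alone, the rest of the molecule is the same in all four compounds, so the effect of a change elsewhere on the number in this assay is also open.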